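From Bromo to Trifluoromethyl: What to Expect of Compound 4

This account rests on a few compounds, and the source may have more. Where it says the series, first, only, none or still open, it means among the compounds named here.

Of the compounds shown here, three built on a shared core have so far been tested in a functional assay on A-431 cells (Homo sapiens) for antiproliferative activity, read by MTT assay, with a stated time of 72 h, tested at 5 uM; a higher number here means more inhibition at the concentration tested (going by the name of the read-out), a lower number less inhibition. Compound 1 `CCOC(=O)/C(C#N)=C(/NNC(=O)c1cc(OC)c(OC)c(OC)c1)N[C@@H](C)c1ccccc1` gives 29.4% in this assay. Compound 2 `CCOC(=O)/C(C#N)=C(/Nc1ccc(C(F)(F)F)cc1)N[C@H](C)c1ccccc1` gives 43.1% in this assay, the highest of the three numbers. Compound 3 `CCOC(=O)/C(C#N)=C(/Nc1ccc(Br)cc1)N[C@@H](C)c1ccccc1` gives 19.3% in this assay, the lowest of the three; its nearest neighbour is compound 1, whose number lies higher by more than the usual scatter, and compound 2 lies further above it, again beyond the scatter.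

Compound 4 `CCOC(=O)/C(C#N)=C(/Nc1ccc(C(F)(F)F)cc1)N[C@@H](C)c1ccccc1` has not yet been measured. It differs from compound 3 in one place: trifluoromethyl in place of bromo on an aromatic carbon. Compound 4 thus carries the same trifluoromethyl group that is found in compound 2, the compound with the highest number in the set. Among the measured compounds shown here, no measured pair in this set is separated by exactly this change, so the size of the step cannot be read off directly; it has to be judged from where compound 2 and compound 3 stand. The estimated step, a number 16.7 percentage points higher from compound 3 to compound 4 (beyond the scatter), is expected to run upward and beyond the scatter. Compound 4 is estimated at 36%, with a likely range from 20% to 52%.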

Compound 4, a percentage reported as inhibition, at one concentration (the size of the read-out at that concentration, not a potency): 39.9%
Estimate against measurement, compound 4: 3.9 percentage points below, within the range that was stated.
By their numbers in this assay, from the lowest: compound 3; then compound 1; then compounds 4 and 2 (each within the scatter of the next).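

In this assay, among the compounds shown here, the exchange on this aromatic carbon, para to a large group, now has a measured size for the first time, since no earlier pair differed in one place: with trifluoromethyl in place of bromo and the configuration as drawn unchanged, the result is a number 20.6 percentage points higher from compound 3 to compound 4 (beyond the scatter). For the compounds shown here, the new compound also gives the first look at the stereocentre at the saturated chain carbon, drawn R in compound 2 and S in compound 4, and the comparison yields a number 3.2 percentage points lower from compound 2 to compound 4 (within the scatter), so the two trifluoromethyl compounds cannot be told apart in this assay. This comparison speaks to configuration alone, with no other structural change mixed in: the fact that compounds 2 and 4 differ only in the configuration as drawn.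

On these data alone, whether chloro, an amine or a carboxylic acid on the same aromatic carbon would give a number closer to that of compound 3 or to that of compound 4 remains open, as does whether the configuration at the chain carbon matters as little when bromo is the group on the ring. Each number also comes from a single concentration, so the potency of these compounds remains undefined.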